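Chalcone series: aryl variation against cytotoxicity

A few compounds are considered here, and "the series" means these few. Any claim that something is new, unique, unknown or untested is made for them only; others in the source may bear on it.

Three compounds sharing one core, differing only in the aryl on the double-bonded chain, have numbers in a functional assay on cells (Tumor Cell line, Homo sapiens) for cytotoxicity; a lower number here means a stronger inhibitor, a higher number a weaker inhibitor. Compound 1 `CN(C)Cc1cc(C(=O)/C=C/c2cccc(Cl)c2)cc(CN(C)C)c1O` gives 4680 nM. Compound 2 `CN(C)Cc1cc(C(=O)/C=C/c2ccc(Cl)cc2Cl)cc(CN(C)C)c1O` gives 3090 nM. Compound 3 `CN(C)Cc1cc(C(=O)/C=C/c2ccc(Cl)c(Cl)c2)cc(CN(C)C)c1O` gives 2350 nM, the lowest number of the three, though it is within the scatter of both others: a 2.0-fold lower number from compound 1 to compound 3 (0.30 log units; within the scatter), a 1.3-fold lower number from compound 2 to compound 3 (0.12 log units; within the scatter), and a 1.5-fold lower number from compound 1 to compound 2 (0.18 log units; within the scatter). No aryl change measured so far has moved the number beyond the scatter.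

Compound 4 `CN(C)Cc1cc(C(=O)/C=C/c2ccc(O)cc2)cc(CN(C)C)c1O` is not yet measured. It differs from compound 3 as follows: 4-hydroxyphenyl in place of 3,4-dichlorophenyl on a double-bonded chain carbon bound to a double-bonded chain carbon.

Among the measured compounds shown here, none of the measured steps bears directly on this change: each of them swaps one chloro pattern for another, whereas here both chlorines leave and a hydroxyl enters. The measured steps show only that rearranging or adding chloro shifts the number little. Because compound 3 sits at 2350 nM and the chloro-bearing variants cluster closely, removal of both chlorines is expected to give a somewhat higher number, though the size is uncertain. The step expected is a 2.8-fold higher number from compound 3 to compound 4 (0.44 log units; beyond the scatter). Compound 4 is estimated at 6500 nM, with a range from 2500 nM to 17000 nM.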

Compound 4, half-maximal inhibitory concentration: 39800 nM
Estimate against measurement, compound 4: 6.1-fold (0.79 log units) below; the measured number lies above the stated range.
By their numbers in this assay, from the lowest: compounds 3, 2 and 1 (each within the scatter of the next); then compound 4.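

At this position on a double-bonded chain carbon bound to a double-bonded chain carbon, the aryl is not indifferent to its substituents: changes among chloro patterns stayed within the scatter, but the 4-hydroxyphenyl group shifts the number in this assay well beyond it. The shift is seen against every chloro-bearing aryl, with a 17-fold higher number from compound 3 to compound 4 (1.23 log units; beyond the scatter), a 13-fold higher number from compound 2 to compound 4 (1.11 log units; beyond the scatter), and an 8.5-fold higher number from compound 1 to compound 4 (0.93 log units; beyond the scatter), so compound 1, compound 2 and compound 3 all stand clearly apart from compound 4, and none of the four goes against this split. Nothing shown gives a reason for the shift.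

This change removes chloro and brings in hydroxyl in a single step, so the compounds shown do not tell whether the higher number follows the loss of chloro, the arrival of hydroxyl, or both. A plain phenyl would address the first of these, while a methoxy group or an amine on the aryl, or a hydroxyl and a chloro on the same ring, would test how specific the effect is to the hydroxyl.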